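The compounds below may be only part of what the source reports. "The series", "measured", "known", "first", "only" and "open" are said of these compounds alone.

Working notes on the series. Going by the values given here, in a functional assay on HeLa cells (Homo sapiens) for antiproliferative activity, with a stated time of 24 h (a higher number here means a weaker inhibitor, a lower number a stronger inhibitor), compound 1 `NC(=O)c1c(NC(=O)c2ccccc2Cl)sc2c1CCN(C(=S)Nc1ccccc1Br)C2` gives 24600 nM, the only true number available so far. Compound 2 `Cc1ccccc1NC(=S)N1CCc2c(sc(NC(=O)c3ccccc3Cl)c2C(N)=O)C1` reads > 50000 nM, which is a limit of the assay and not a number.

Compound 3 `Cc1ccccc1C(=O)Nc1sc2c(c1C(N)=O)CCN(C(=S)Nc1ccccc1Br)C2` keeps the shared core and the bromo group of compound 1, and alters the other aromatic ring: methyl in place of chloro on an aromatic carbon. This is methyl in place of chloro on an aromatic carbon, ortho to a large group.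

Among the compounds with values here, one measured step bears on this change: an at least 2.0-fold higher number from compound 1 to compound 2 (0.30 log units; that floor lies within the scatter). It is also a methyl replacing a halogen on an aromatic carbon, but the halogen is bromo and the site is a different one, so it offers only a rough guide. Its size is known only as a floor, and that floor does not clear the scatter.

In this assay, a small move towards a higher number is therefore expected, possibly none beyond the scatter. The expected step is a 1.3-fold higher number from compound 1 to compound 3 (0.13 log units; within the scatter).

For compound 3, the estimated value is 33000 nM, with an expected range of 16000 nM to 60000 nM.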

Compound 3, half-maximal inhibitory concentration: > 50000 nM
Compound 3 gave a limit, no number (the forecaster's own chance of this, stated with the estimate: 35%); middle value at least 1.5-fold (0.18 log units) from the limit.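

Compound 3 reads > 50000 nM in this assay, which is a limit of the assay and not a number, so the change from 2-chlorophenyl to 2-methylphenyl has no measured size. What can be stated is an at least 2.0-fold higher number from compound 1 to compound 3 (0.30 log units; that floor lies within the scatter), and methyl has now replaced a halogen at each of the two aromatic sites of compound 1 without a true number resulting from either replacement. Both steps remain floors and not sizes because the values sit at a limit: the limit of > 50000 nM in this assay, at which 2 of the 3 values shown sit.

Going by these compounds alone, whether methyl on this ring truly moves the number beyond the scatter, or how far, remains open, since compound 1 is the only compound here with a true number. Also open, from the compounds shown here alone, is how an amine, a methoxy group or a plain hydrogen in place of chloro on the 2-chlorophenyl ring would read in this assay, and whether any such group would give a true number on either side of compound 1.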